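Cyclopropyl for Isopropyl on the Ring Imide Nitrogen

This account rests on a few compounds, and the source may have more. Where it says the series, first, only, none or still open, it means among the compounds named here.

Compound 1 `CCN1C(=O)CN(Cc2ccc(-c3cccc(CN4CCCCC4)n3)cc2)C1=O` in a physicochemical assay for acid dissociation: 8.8
Compound 2 `CN1C(=O)CN(Cc2ccc(-c3cccc(CN4CCCCC4)n3)cc2)C1=O` in this assay: 8.7
Compound 3 `CC(C)N1C(=O)CN(Cc2ccc(-c3cccc(CN4CCCCC4)n3)cc2)C1=O` in this assay: "not determined" (no result reported)

Among the measured compounds shown here, the step of a number 0.10 log units lower from compound 1 to compound 2 (within the scatter) is the only measured change on this nitrogen, and it lies within the scatter. For compound 3 no number exists in this assay, so it stands only by its structure, which shares the core of compound 1 and compound 2.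

Compound 4 `O=C1CN(Cc2ccc(-c3cccc(CN4CCCCC4)n3)cc2)C(=O)N1C1CC1` differs from compound 3 by cyclopropyl in place of isopropyl on an amide-type nitrogen in a ring. For the measured compounds named here, the one measured step at this position did not move the value beyond the scatter, and no step bears on the piperidine part of the core.

Compound 4 is therefore expected to stay near the values of compound 1 and compound 2, with an estimate of 8.75 and a range from 8.4 to 9.1.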

Compound 4, acid dissociation constant: 9
Compound 4: middle estimate off by 0.25 log units, on the low side; the measured number falls inside the stated range.
By their numbers in this assay, from the lowest: compounds 2, 1 and 4 (each within the scatter of the next).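

Among the compounds shown here, with compound 4, a ring stands for the first time on this amide-type nitrogen in a ring. In this assay the steps read a number 0.30 log units higher from compound 2 to compound 4 (within the scatter) and a number 0.20 log units higher from compound 1 to compound 4 (within the scatter), so cyclopropyl sits within the scatter of both methyl and ethyl at this position. Nothing available offers an explanation for these readings.

The compounds shown leave open whether a longer chain, such as butyl, or a chain carrying an amine or a carboxylic acid on this nitrogen would stay within the scatter. They also leave open how the number responds to replacing the piperidine part of the core.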